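The compounds below may be only part of what the source reports. "The series", "measured", "known", "first", "only" and "open" are said of these compounds alone.

Working notes on the series. The shared core of compound 1 `COC(=O)C1=C(C)N=C(C)/C(=C(\O)OC)C1c1ccc(Cl)cc1` carries a 4-chlorophenyl group on a saturated ring carbon; in a functional assay (muscle tissue) with Cavia porcellus as the target (on this read-out lower numbers stand for an effect already at smaller amounts and higher numbers for an effect only at larger amounts of compound), compound 1 gives 8130 nM. Compound 2 `COC(=O)C1=C(C)N=C(C)/C(=C(\O)OC)C1c1ccccc1N` carries a 2-aminophenyl group instead and gives 39800 nM in this assay, a step of a 4.9-fold higher number from compound 1 to compound 2 (0.69 log units; beyond the scatter). Compound 3 `COC(=O)C1=C(C)N=C(C)/C(=C(\O)OC)C1c1ccccc1Br` carries a 2-bromophenyl group and gives 7.59 nM in this assay, the lowest of the three numbers, with steps of a 1100-fold lower number from compound 1 to compound 3 (3.03 log units; beyond the scatter) and of a 5200-fold lower number from compound 2 to compound 3 (3.72 log units; beyond the scatter).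

Compound 4 `COC(=O)C1=C(C)N=C(C)/C(=C(\O)OC)C1c1ccccc1OC` is the next candidate. The change from compound 3 is methoxy in place of bromo on an aromatic carbon. Of the measured steps, the exchange of the group on the aromatic carbon in compound 2 against that of compound 3 bears most directly: a 5200-fold lower number from compound 2 to compound 3 (3.72 log units; beyond the scatter) shows that a different group in the same place can move the number by a large amount, and compound 2 sitting far above compound 1 shows that a group in that place does not by itself secure a low number. Methoxy has not been measured in any position. A rise from the number of compound 3 is therefore expected, of modest to large size, but well short of the amino case.

Compound 4 is estimated at 150 nM, with a likely range from 15 nM to 2000 nM, a step of a 20-fold higher number from compound 3 to compound 4 (1.30 log units; beyond the scatter) expected in this assay.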

Compound 4, half-maximal effective concentration: 57.5 nM
Compound 4: middle estimate off by 2.6-fold (0.42 log units), on the high side; low and high end bracket the measured number.
By their numbers in this assay, from the lowest: compound 3; then compound 4; then compound 1; then compound 2.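

In this assay a second group on this aromatic carbon, ortho to a large group, now gives a number far under that of the 4-chlorophenyl compound (a 140-fold lower number from compound 1 to compound 4 (2.15 log units; beyond the scatter)), so the low number of compound 3 is not tied to bromo alone. Methoxy still gives up ground against bromo (a 7.6-fold higher number from compound 3 to compound 4 (0.88 log units; beyond the scatter)), yet that step is modest beside the large one from the amino compound (a 690-fold lower number from compound 2 to compound 4 (2.84 log units; beyond the scatter)), which leaves amino as the one group of the three at this place that goes against a low number. Nothing measured here accounts for the order of bromo, methoxy and amino, so the numbers give a ranking of these groups and no reason for it.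

Open, going by these compounds, is where chloro, methyl, nitro or a longer ether such as ethoxy would fall on this same aromatic carbon, whether with bromo and methoxy or nearer amino. Also open, on these data alone, is whether bromo or methoxy would keep a low number on the carbon that carries chloro in compound 1, since compound 1 and compound 3 differ in both the group and its place.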